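From dimethylamino to formyl on the shared core

The source may hold more compounds than are shown below. What is called first, only, known or untested is meant among the compounds shown, and "the series" means these compounds.

Compound 1 `Cc1cccc2c1nc(-c1c(F)cccc1F)n2Cc1c(F)cccc1F`: > 100 uM (a limit)
Compound 2 `CN(C)c1cccc2c1nc(-c1c(F)cccc1F)n2Cc1c(F)cccc1F`: > 100 uM (a limit)

In a toxicity assay on CCRF-CEM cells (Homo sapiens) for cytotoxicity (a lower number here means that less compound is tolerated, a higher number that more compound is tolerated), compound 2 gives > 100 uM, which is a limit of the assay and not a number. It has no readable position relative to compound 1, as the evidence shows: the limit of > 100 uM in this assay, at which 2 of the 2 values shown sit. Compound 3 `O=Cc1cccc2c1nc(-c1c(F)cccc1F)n2Cc1c(F)cccc1F` keeps the shared core and differs from compound 2 at one place: formyl in place of dimethylamino on an aromatic carbon. Going by the values given here, the only measured step that bears on this change is a step that the two limits leave unreadable from compound 1 to compound 2, which also replaces the group on that aromatic carbon. Its size cannot be read, so it offers neither a size nor a direction, and no step beyond the scatter is expected in this assay. The expected step is a number no higher from compound 2 to compound 3 (the limit leaves the size open). For compound 3 the estimated value is 100 uM, with an expected range from 40 uM to 200 uM.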

Compound 3, half-maximal toxic concentration: 0.82 uM
Compound 3: middle estimate off by 120-fold (2.09 log units), on the high side, and the stated range ends above it.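

In this assay, going by these compounds alone, the earlier compounds gave no readable difference at this aromatic carbon, but the group placed there now proves able to change the outcome sharply: formyl in place of dimethylamino gives a large drop (an at least 120-fold lower number from compound 2 to compound 3 (2.08 log units; beyond the scatter)). Formyl in place of methyl gives a drop of the same printed size (an at least 120-fold lower number from compound 1 to compound 3 (2.08 log units; beyond the scatter)), so across these three compounds the change appears with either group leaving, and only compound 3, with formyl, stands apart. Both steps are open-ended, and their full size cannot be read: the limit of > 100 uM in this assay, at which 2 of the 3 values shown sit.

From the compounds shown here alone, whether a hydroxymethyl, a carboxylic acid or an amide on this aromatic carbon would side with formyl or with methyl and dimethylamino remains open. The compounds shown also leave open whether formyl would have the same effect on another position of the shared core.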